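Triazole series: amide swap at the indolylmethyl nitrogen

The source may report more compounds than this note shows. Statements on the series, on what has been measured and on what is new or still open speak of the compounds shown alone.

Compound 1 `COc1ccc(Cn2c(CCc3ccccc3)nnc2[C@H](NC(=O)C(C)(C)N)c2c[nH]c3ccccc23)cc1` gives 11 nM in an in vitro assay on LLC-PK1 cells for displacement of a labelled ligand from growth hormone secretagogue receptor type 1 (Homo sapiens); a higher number here means a weaker inhibitor, a lower number a stronger inhibitor.
Compound 2 `COc1ccc(Cn2c(CCc3c[nH]c4ccccc34)nnc2[C@H](NC(=O)c2ccccn2)c2c[nH]c3ccccc23)c(OC)c1` gives 1.8 nM in this assay.
Compound 3 `COc1ccc(-n2c(CCc3ccccc3)nnc2[C@H](NC(=O)c2ccccn2)c2c[nH]c3ccccc23)c(OC)c1` gives 33 nM in this assay.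

Three compounds are measured. Compound 1 stands second highest of the three numbers: compound 3 sits a step above it, beyond the scatter, and compound 2 sits well below it, also beyond the scatter. Among the measured compounds shown here, compound 2 and compound 3 both carry a pyridin-2-yl carbonyl on the amide nitrogen, yet they differ from compound 1 in more than one place, so no single step to either is available; their two values simply bracket compound 1 on both sides.

Compound 4 `COc1ccc(Cn2c(CCc3ccccc3)nnc2[C@H](NC(=O)c2ccncc2)c2c[nH]c3ccccc23)cc1` is not yet measured. It differs from compound 1 in one place: pyridin-4-yl in place of 1-amino-1-methylethyl on a carbonyl carbon. For the measured compounds named here, no measured pair shows this change on its own. The replacement of the 1-amino-1-methylethyl group, which brings one hydrogen-bond donor, by a pyridin-4-yl ring with none is expected to cost some potency, and the step from compound 1 to compound 4 is estimated at a 3.6-fold higher number from compound 1 to compound 4 (0.56 log units; beyond the scatter), a loss beyond the scatter but not a large one. Compound 4 is therefore expected to give about 40 nM in this assay, most likely between 10 nM and 160 nM.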

Compound 4, half-maximal inhibitory concentration: 220 nM
Beside the measured number, compound 4's estimate is 5.5-fold (0.74 log units) below it; the measured number lies above the stated range.
By their numbers in this assay, from the lowest: compound 2; then compound 1; then compound 3; then compound 4.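

Among the compounds shown here, the first single-place step falls on the carbonyl carbon of the amide: pyridin-4-yl in place of 1-amino-1-methylethyl gives a 20-fold higher number from compound 1 to compound 4 (1.30 log units; beyond the scatter) in this assay and is large. With the rest of the structure unchanged, the group on this carbonyl carbon alone can therefore weaken inhibition substantially, and an aromatic ring bearing one nitrogen does not stand in here for 1-amino-1-methylethyl on the core of compound 1. Nothing measured here explains the size of this step.

Going by these compounds, compound 2 and compound 3 also carry a pyridine ring on the carbonyl carbon, but each differs from compound 4 in more than one place, so those steps cannot be read and the effect of the ring nitrogen's location stays open. Also open, on these data alone, is whether the change turns on losing the amine or on bringing in the ring; an isopropyl group on the same carbonyl carbon would separate the two.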